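Replacing Pyrrolidin-1-yl with Diethylamino: an Expected Step

The compounds below may be only part of what the source reports. "The series", "measured", "known", "first", "only" and "open" are said of these compounds alone.

Measured compounds:
compound 1 `CCN(CC)CCNC(=O)CC(CC(=O)NC1Cc2ccccc2C1)c1ccc(Cl)cc1`: 50500 nM
compound 2 `O=C(CC(CC(=O)NC1Cc2ccccc2C1)c1ccc(Cl)cc1)NCCN1CCCC1`: 77300 nM
compound 3 `CCN(C(=O)CC(CC(=O)NCCN1CCCC1)c1ccc(Cl)cc1)C1Cc2ccccc2C1`: 36400 nM

All three were tested in a functional assay on HeLa cells (Homo sapiens) for inhibition; on this read-out higher numbers stand for weaker inhibition and lower numbers for stronger inhibition. Compound 2 and compound 3 differ in their cores: ethyl in place of hydrogen on an amide-type nitrogen. That change gave a 2.1-fold lower number from compound 2 to compound 3 (0.33 log units; beyond the scatter). Compound 2 and compound 1 differ only in the amine tail: diethylamino in place of pyrrolidin-1-yl on a saturated chain carbon, two bonds along the chain from an amide-type nitrogen. That step gave a 1.5-fold lower number from compound 2 to compound 1 (0.18 log units; within the scatter).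

Compound 4 `CCN(CC)CCNC(=O)CC(CC(=O)N(CC)C1Cc2ccccc2C1)c1ccc(Cl)cc1` has not yet been measured. It differs from compound 3 in the same way that compound 1 differs from compound 2: diethylamino in place of pyrrolidin-1-yl on a saturated chain carbon, two bonds along the chain from an amide-type nitrogen. The place line of this change is the same word for word in both pairs, so it is the same change, made here on the core of compound 3 rather than that of compound 2.

Compound 4 is expected to show a 1.5-fold lower number from compound 3 to compound 4 (0.16 log units; within the scatter) because a 1.5-fold lower number from compound 2 to compound 1 (0.18 log units; within the scatter) for the same change stayed within the scatter. The number for compound 4 is accordingly estimated at 25000 nM, with a likely range from 10000 nM to 60000 nM.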

Compound 4, half-maximal inhibitory concentration: 24300 nM
The estimate for compound 4 lay 1.0-fold (0.01 log units) above the measured number, and the stated range covers the measured number.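

In this assay, diethylamino in place of pyrrolidin-1-yl on the core of compound 3 gave a 1.5-fold lower number from compound 3 to compound 4 (0.18 log units; within the scatter), and this step matched the one seen earlier on the core of compound 2: the same change on two cores in this assay, a 1.5-fold lower number (0.18 log units; within the scatter) from compound 2 to compound 1 and a 1.5-fold lower number (0.18 log units; within the scatter) from compound 3 to compound 4, 1.0-fold (0.01 log units) apart, within the scatter of two such steps. With the diethylamino tail in place, ethyl in place of hydrogen on an amide-type nitrogen gave a 2.1-fold lower number from compound 1 to compound 4 (0.32 log units; beyond the scatter), and this change also carried over: the same change on two cores in this assay, a 2.1-fold lower number (0.33 log units; beyond the scatter) from compound 2 to compound 3 and a 2.1-fold lower number (0.32 log units; beyond the scatter) from compound 1 to compound 4, 1.0-fold (0.01 log units) apart, within the scatter of two such steps. These results show that each change behaved alike on the two cores shown, but the amine swap stayed within the scatter on both, so they do not establish that it alters inhibition, and four compounds cannot show that either change would carry over to other cores.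

The compounds shown leave open whether a piperidin-1-yl or morpholin-4-yl tail, or a longer chain such as 3-(diethylamino)propyl, would fit the same picture. They also leave open whether propyl in place of ethyl on the amide-type nitrogen would give a step of similar size.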